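A Third Fluorine on the Difluorostilbene Core

The source may hold more compounds than are shown below. What is called first, only, known or untested is meant among the compounds shown, and "the series" means these compounds.

Two stilbenes carrying fluorine on both rings have been tested so far. Within the data shown here, in an assay on HepG2 cells for activation of nuclear factor erythroid 2-related factor 2 (Homo sapiens), read by a luciferase reporter, with a stated time of 5 h (on this read-out higher numbers stand for an effect only at larger amounts of compound and lower numbers for an effect already at smaller amounts), compound 2 (`Fc1ccccc1/C=C/c1ccccc1F`) gives 4300 nM, the only proper number among the values shown. Compound 1 (`Fc1cccc(/C=C/c2ccccc2F)c1`) reached only a limit of the assay: in this assay compound 1 gives > 15000 nM, sitting at the limit of > 15000 nM in this assay, at which 1 of the 2 values shown sits. Compound 3 (`Fc1ccc(F)c(/C=C/c2ccccc2F)c1`) has not yet been measured. It differs from compound 2 by fluoro in place of hydrogen on an aromatic carbon, a fluoro in place of hydrogen on an aromatic carbon. Among the measured compounds shown here, no pair of measured compounds shows what such an added fluorine does, so there is no measured step to lean on. A change this small is expected to shift the read-out little, if at all, and the step of a 1.2-fold lower number from compound 2 to compound 3 (0.09 log units; within the scatter) is therefore expected to stay close to the usual scatter. In this assay compound 3 is estimated at 3500 nM, with a plausible range from 1200 nM to 10000 nM.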

Compound 3, half-maximal effective concentration: 5900 nM
Compound 3: the middle estimate sits 1.7-fold (0.23 log units) below what was measured; the range from low to high includes it.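

In this assay, a third fluorine placed para to a fluoro group and meta to a group of 9 heavy atoms makes no difference that can be told from the scatter, with a 1.4-fold higher number from compound 2 to compound 3 (0.14 log units; within the scatter). The same exchange of hydrogen for fluoro, read from the other direction, does reach beyond the scatter, with an at least 2.5-fold lower number from compound 1 to compound 3 (0.40 log units; beyond the scatter), so on this core the effect of one added fluorine depends on where the fluorines already sit. Compound 1 carries only a limit of the assay, not a number: the limit of > 15000 nM in this assay, at which 1 of the 3 values shown sits.

The compounds shown carry only fluorine as a substituent, so it stays open whether a larger or different group at this place, such as a methoxy group, an amine or a carboxylic acid, would move the read-out beyond the scatter. They also leave open whether a chlorine or a hydroxyl elsewhere on the shared core would do so.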